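The compounds below may be only part of what the source reports. "The series", "measured", "known", "first", "only" and "open" are said of these compounds alone.

In an ADME assay on CCRF-HSB-2 cells (Homo sapiens) for cytotoxicity, with a stated time of 7 days (on this read-out lower numbers stand for higher toxicity in this test and higher numbers for lower toxicity in this test), compound 1 `CCCCCCCCOc1nc(N)nc2c1ncn2/C=C1/CC1(CO)CO` gives > 20000 nM as a limit of the assay and not a number. Compound 2 `Nc1nc(NCc2ccccc2)c2ncn(/C=C3/CC3(CO)CO)c2n1` gives > 20000 nM as a limit too, so it stands with no exact number (the limit of > 20000 nM in this assay, at which 2 of the 2 values shown sit). Among the compounds with values here, the one measured step (a step that the two limits leave unreadable from compound 1 to compound 2) has no readable size and is the only guide. Compound 3 `CC(C)Nc1nc(N)nc2c1ncn2/C=C1/CC1(CO)CO` differs from compound 2 (isopropyl in place of benzyl on a nitrogen on an aromatic ring): isopropyl in place of benzyl on a nitrogen on an aromatic ring. With no size to carry over, the expected step (a number no higher from compound 2 to compound 3 (the limit leaves the size open)) stays within the scatter, in neither direction. Compound 3 has an estimated value of 20000 nM (expected range 8000 nM to 40000 nM).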

Compound 3, half-maximal cytotoxic concentration: > 20000 nM
Compound 3: no number, only a limit; the forecaster's own chance of this, stated with the estimate: 80%; the middle value sits exactly at the limit.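

In this assay no step can be read among compound 1, compound 2 and compound 3, because all three give a limit of the assay and not a number: the limit of > 20000 nM in this assay, at which 3 of the 3 values shown sit.
From the compounds shown here alone, whether octyloxy, benzylamino or isopropylamino on the shared core changes the toxicity in this test stays open.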